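The compounds below may be only part of what the source reports. "The series", "measured", "known", "first", "only" and "open" are said of these compounds alone.

Measured compounds:
- compound 1, `CCOC(=O)c1c(-c2ccc(OC)c(OC)c2)csc1N`, in an assay on isolated protein for inhibition of protein kinase C zeta type (Homo sapiens), with stated times of 1 h and 2.5 min, tested at 30 uM (on this read-out higher numbers stand for more inhibition at the one concentration tested (going by the name of the read-out) and lower numbers for less inhibition), gives 100%
- compound 2, `COc1ccc(-c2csc(N)c2C(=O)OCc2cccc(C)c2)cc1OC`, in this assay gives 67%

Compound 2 stands lowest of the two numbers measured in this assay; its nearest neighbour is compound 1, which lies higher by a number 33 percentage points lower from compound 1 to compound 2 (beyond the scatter), a step beyond the scatter. Among the measured compounds shown here, that step changed the ester part of the shared core, and it is the only measured step available.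

Compound 3, `COc1ccc(-c2csc(N)c2C(=O)OCc2ccc(C)cc2)cc1OC`, has not yet been measured. It differs from compound 2 only in where the methyl sits on the aromatic ring of the ester: 4-methylphenyl in place of 3-methylphenyl on a saturated chain carbon bound to an oxygen next to a carbonyl group. The two compounds hold the same atoms, joined differently.

For the measured compounds named here, no measured step touches this kind of change; the step from compound 1 to compound 2 swapped a whole group in and out rather than moving a methyl around a ring, so it bears on compound 3 only by showing that this part of the molecule can matter. With nothing else to go on, the expected step in this assay is none beyond the scatter: a number 2 percentage points lower from compound 2 to compound 3 (within the scatter). Compound 3 is therefore estimated to give 65%, within a range of 40% to 90%.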

Compound 3, a percentage reported as inhibition, at one concentration (the size of the read-out at that concentration, not a potency): 50%
The estimate for compound 3 lay 15 percentage points above the measured number; the range from low to high includes it.
By their numbers in this assay, from the lowest: compound 3; then compound 2; then compound 1.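

Moving one methyl on the ester's aromatic ring, with no atom gained or lost, shifts the read-out in this assay beyond the scatter (a number 17 percentage points lower from compound 2 to compound 3 (beyond the scatter)). Compound 2 had shown only that replacing the methyl of the ethyl ester with 3-methylphenyl could change the number, whereas this result shows that the arrangement within the new group matters as well, and that the ring's presence alone does not set the value. The 4-methylphenyl replacement also stands well apart from the original ester (a number 50 percentage points lower from compound 1 to compound 3 (beyond the scatter)), but no measurement here explains why these two arrangements of the same atoms differ.

The compounds shown leave open whether a plain phenyl ring without a methyl, or a 4-chlorophenyl group, would fall near compound 1 or nearer compound 3, so the methyl's own contribution cannot yet be separated from that of the ring. They also leave open how an amide or a carboxylic acid in place of the ester would read, and each number remains a single-concentration result rather than a measure of potency.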